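The source may hold more compounds than are shown below. What is called first, only, known or untested is meant among the compounds shown, and "the series" means these compounds.

In a functional assay on HepG2 cells (Homo sapiens) for antiproliferative activity, read by MTT assay, with a stated time of 48 h (a lower number here means a stronger inhibitor, a higher number a weaker inhibitor), compound 1 `COc1ccc(-c2ccc3c(c2)C(=O)C(=O)N3Cc2ccc(Cl)cc2)cc1` gives 250 nM and compound 2 `COc1ccc(-c2ccc3c(c2)C(=O)C(=O)N3Cc2ccc(C)cc2)cc1` gives 330 nM as measured values. Among the measured compounds shown here, the only measured step, methyl in place of chloro, is a 1.3-fold higher number from compound 1 to compound 2 (0.12 log units; within the scatter) and it does not touch the group changed next. Compound 3 `COc1ccc(CN2C(=O)C(=O)c3cc(-c4ccc(OC)c(OC)c4)ccc32)cc1` gives > 10000 nM and this is a limit, not a number. Compound 4 `COc1ccc(CN2C(=O)C(=O)c3cc(-c4ccc(C)cc4)ccc32)cc1` differs from compound 3 by 4-methylphenyl in place of 3,4-dimethoxyphenyl on an aromatic carbon with 4-methylphenyl in place of 3,4-dimethoxyphenyl on an aromatic carbon. For the measured compounds named here, no measured step covers this change, so its size is uncertain. Compound 2 at 330 nM offers only a loose guide, yet a move toward a lower number is expected. The expected change is an at least 6.6-fold lower number from compound 3 to compound 4 (0.82 log units; beyond the scatter) on this estimate. For compound 4 the estimated value is 1500 nM within an expected range of 300 nM to 8000 nM in this assay once measured.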

Compound 4, half-maximal inhibitory concentration: > 10000 nM
Compound 4: only a limit was reported; the forecaster's own chance of this, stated with the estimate: 25%; middle value at least 6.6-fold (0.82 log units) away from the limit.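

Compound 3 and compound 4 both stand only as limits, not numbers, so no step between them can be read: the limit of > 10000 nM in this assay, at which 2 of the 4 values shown sit.

From the compounds shown here alone, whether 4-methylphenyl in place of 3,4-dimethoxyphenyl changes activity at all remains open.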